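This account rests on a few compounds, and the source may have more. Where it says the series, first, only, none or still open, it means among the compounds named here.

Compound 1 `CC(=O)N1N=C(c2ccc(N3CCN(C)CC3)cc2)CC1c1ccc(N(C)C)cc1` is the reference point. Among the compounds with values here, in a functional assay on NCI-H1975 cells (Homo sapiens) for inhibition, read by sulforhodamine B assay, tested at 10 uM (on this read-out lower numbers stand for less inhibition and higher numbers for more inhibition at the one concentration tested (going by the name of the read-out)), compound 1 gives -1.9%, the lowest of the two numbers in hand, though only within the scatter of its one neighbour. Within the data shown here, compound 2 `CN1CCN(c2ccc(C3=NN(S(C)(=O)=O)C(c4ccc(N(C)C)cc4)C3)cc2)CC1` gives -1.3% in this assay, and the step of a number 0.6 percentage points higher from compound 1 to compound 2 (within the scatter) is the only measured change bearing on the present question. Compound 3 `CN1CCN(c2ccc(C3=NN(S(=O)(=O)c4ccc(F)cc4)C(c4ccc(N(C)C)cc4)C3)cc2)CC1` carries the change ((4-fluorophenyl)sulfonyl in place of acetyl on an amine nitrogen in a ring). Among the measured compounds shown here, since the one comparable change stayed within the scatter, no step beyond it is expected in this assay for compound 3, and its expected value is 1%, between -12% and 16%, an expected step of a number 2.9 percentage points higher from compound 1 to compound 3 (within the scatter).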

Compound 3, a percentage reported as inhibition, at one concentration (the size of the read-out at that concentration, not a potency): 95.7%
Compound 3: middle estimate off by 94.7 percentage points, on the low side; measured number outside the range, above it.
By their numbers in this assay, from the lowest: compounds 1 and 2 (each within the scatter of the next); then compound 3.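

In this assay the substituent on the amine nitrogen in the ring clearly matters: (4-fluorophenyl)sulfonyl in place of acetyl gives a number 97.6 percentage points higher from compound 1 to compound 3 (beyond the scatter) and so goes far beyond the earlier change at this position. With the sulfonyl kept, 4-fluorophenyl in place of methyl on the sulfonyl sulfur gives a number 97 percentage points higher from compound 2 to compound 3 (beyond the scatter) and shows that sulfonyl alone does not carry the step in this pair. No measurement bears on the reason for the step. Open, on these data alone, is whether a plain phenyl or a thiophene on the sulfonyl keeps this number, and so whether the fluorine matters. A single concentration also gives no potency.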